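This account rests on a few compounds, and the source may have more. Where it says the series, first, only, none or still open, it means among the compounds named here.

Compound 1 `Cc1cnc(C(=O)N[C@H]2CCOC[C@@H]2O)cc1Cc1ccc(-n2cccn2)cc1`: in an ADME assay on microsomes from liver (Homo sapiens) for metabolic stability (on this read-out higher numbers stand for fast clearance and lower numbers for slow clearance), compound 1 gives < 8 mL/min/kg, which is a limit of the assay and not a number.
Compound 2 `Cc1cnc(C(=O)N[C@H]2CCOC[C@@H]2O)cc1Cc1ccc(-c2cocn2)cc1`: in this assay compound 2 gives < 8 mL/min/kg, again a limit of the assay.

Going by the values given here, compound 2 thus stands at the lower edge of what this assay reports, the same edge at which every value so far sits (the limit of < 8 mL/min/kg in this assay, at which 2 of the 2 values shown sit). Among the compounds with values here, the only measured step, a step that the two limits leave unreadable from compound 1 to compound 2, swaps one five-membered aromatic ring for another and cannot be read in size; both ends are limits. Compound 3 `Cc1cnc(C(=O)N[C@H]2CCOC[C@@H]2O)cc1Cc1ccc(-c2cscn2)cc1` differs from compound 2 in one place: 1,3-thiazol-4-yl in place of 1,3-oxazol-4-yl on an aromatic carbon. This is again an exchange of one five-membered aromatic ring with two hetero atoms for another, so the measured step bears on it but gives no size. With compound 2 at the limit, compound 3 is expected to show a step that the limit leaves unreadable from compound 2 to compound 3, that is, none readable beyond the scatter. Compound 3 is estimated at 6 mL/min/kg, between 3 mL/min/kg and 13 mL/min/kg.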

Compound 3, clearance: < 8 mL/min/kg
Compound 3: a limit, no number (the forecaster's own chance of this, stated with the estimate: 70%); the middle value lies beyond the limit too.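

Going by these compounds alone, compound 3 gives a limit of the assay and not a number in this assay, so no step among compound 1, compound 2 and compound 3 can be read: the limit of < 8 mL/min/kg in this assay, at which 3 of the 3 values shown sit. Going by these compounds, how far these three compounds differ in clearance, if at all, stays open.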